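Neopentyl for Tert-Butyl on a Second Core

The source may report more compounds than this note shows. Statements on the series, on what has been measured and on what is new or still open speak of the compounds shown alone.

Compound 1 `CC(C)(C)[C@@H](O)C(=O)N1OCC[C@H]1C(=O)NCc1cc(Cl)ccc1-n1cnnn1` and compound 2 `CC(C)(C)C[C@@H](O)C(=O)N1OCC[C@H]1C(=O)NCc1cc(Cl)ccc1-n1cnnn1` share one core and differ in a single spot: neopentyl in place of tert-butyl on a saturated chain carbon bound to a carbonyl carbon and an oxygen on a saturated carbon. In a functional assay on a cell-free system (plasma, Homo sapiens), with a stated time of 3 min (on this read-out higher numbers stand for weaker inhibition and lower numbers for stronger inhibition), compound 1 gives 1600 nM. In this assay compound 2 gives 1100 nM. The step between the pair, a 1.5-fold lower number from compound 1 to compound 2 (0.16 log units; within the scatter), is small enough that the two numbers cannot be told apart with confidence.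

Compound 3 `CC(C)(C)[C@@H](O)C(=O)N1NCC[C@H]1C(=O)NCc1cc(Cl)ccc1-n1cnnn1` is built on a different core; the difference between the two cores is not broken down here. In this assay compound 3 gives 1700 nM. That number sits within the scatter of the values of compound 1 and compound 2, so no order among the three can be claimed.

Compound 4 `CC(C)(C)C[C@@H](O)C(=O)N1NCC[C@H]1C(=O)NCc1cc(Cl)ccc1-n1cnnn1` stands to compound 3 as compound 2 stands to compound 1: neopentyl in place of tert-butyl on a saturated chain carbon bound to a carbonyl carbon and an oxygen on a saturated carbon. The surroundings of the change are the same word for word, so this is the same change on the second core. Because the same change earlier gave a 1.5-fold lower number from compound 1 to compound 2 (0.16 log units; within the scatter), a similar step is expected here, a 1.4-fold lower number from compound 3 to compound 4 (0.15 log units; within the scatter), in this assay. Compound 4 is therefore estimated at 1200 nM in this assay, most likely between 600 nM and 2400 nM. The measurement will show whether the second core follows the first.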

Compound 4, half-maximal inhibitory concentration: 1300 nM
Beside the measured number, compound 4's estimate is 1.1-fold (0.03 log units) below it, within the range that was stated.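

Carried to the second core, neopentyl in place of tert-butyl gives a 1.3-fold lower number from compound 3 to compound 4 (0.12 log units; within the scatter) in this assay. Set beside the step on the first core, the two results do not differ: the same change on two cores in this assay, a 1.5-fold lower number (0.16 log units; within the scatter) from compound 1 to compound 2 and a 1.3-fold lower number (0.12 log units; within the scatter) from compound 3 to compound 4, 1.1-fold (0.05 log units) apart, within the scatter of two such steps. This shows that the change behaves alike on both cores, but what carries over is a step too small to be told from scatter, so it does not show that neopentyl gives stronger inhibition than tert-butyl on either core, nor that the agreement would hold on any further core.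

From the compounds shown here alone, only tert-butyl and neopentyl appear on the saturated chain carbon bound to a carbonyl carbon and an oxygen on a saturated carbon, so it remains open whether a longer chain, an amine or a carboxylic acid at that place would move the number beyond the scatter. Going by these compounds, it also remains open whether such a larger step would carry from one core to the other as this small one does.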